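Pyrazinyl for pyridinyl in two hydrazone urea series

The compounds below may be only part of what the source reports. "The series", "measured", "known", "first", "only" and "open" are said of these compounds alone.

Compound 1, `CCN(CC)Cc1ccc2nc(NC(=O)N/N=C(\C)c3ccccn3)sc2c1`, in a functional assay on MCF7 cells (Homo sapiens) for antiproliferative activity, read by CCK-8 assay, with a stated time of 24 h (a higher number here means a weaker inhibitor, a lower number a stronger inhibitor), gives > 40000 nM, which is a limit of the assay.
Compound 2, `CCN(CC)Cc1ccc2nc(NC(=O)N/N=C(\C)c3cnccn3)sc2c1`, in this assay gives > 40000 nM, also a limit.
Compound 3, `C/C(=N\NC(=O)Nc1ccc(CN2CCC(C)CC2)cc1)c1ccccn1`, in this assay gives > 40000 nM, again a limit.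

All three measured compounds sit at the same limit (the limit of > 40000 nM in this assay, at which 3 of the 3 values shown sit), so none of them can be ordered against another. Compound 1 and compound 2 differ only in one change, (pyrazin-2-yl in place of pyridin-2-yl on a carbon with a double bond to nitrogen), and the step that the two limits leave unreadable from compound 1 to compound 2 cannot be read because both values are limits. The difference between the core of compound 1 and the core of compound 3 is not broken down here.

Compound 4, `C/C(=N\NC(=O)Nc1ccc(CN2CCC(C)CC2)cc1)c1cnccn1`, has not yet been measured in this assay. It differs from compound 3 by pyrazin-2-yl in place of pyridin-2-yl on a carbon with a double bond to nitrogen, the same change as from compound 1 to compound 2. The step that the limit leaves unreadable from compound 3 to compound 4 is expected to be unreadable in the same way, resting on the unreadable step that the two limits leave unreadable from compound 1 to compound 2 and on compound 3 sitting at > 40000 nM. Compound 4 is therefore expected to give about 60000 nM, between 30000 nM and 150000 nM, most likely reported as a limit again.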

Compound 4, half-maximal inhibitory concentration: > 40000 nM
Compound 4: a limit, no number; the forecaster's own chance of this, stated with the estimate: 85%; the middle value does not contradict the limit.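

In this assay compound 4 gives > 40000 nM as a limit of the assay, so no step can be read from compound 3 to compound 4, just as none can be read from compound 1 to compound 2. The compounds shown leave open whether pyrazin-2-yl in place of pyridin-2-yl alters antiproliferative activity in either series.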